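A few compounds are considered here, and "the series" means these few. Any claim that something is new, unique, unknown or untested is made for them only; others in the source may bear on it.

Measured in a functional assay on DU-145 cells (Homo sapiens) for antiproliferative activity, read by MTT assay, with a stated time of 72 h; a lower number here means a stronger inhibitor, a higher number a weaker inhibitor:
- compound 1 `O=C(COc1ccc(C(=O)/C=C/c2ccccc2Cl)cc1)N[C@H]1CCOC1=O`: 3240 nM
- compound 2 `O=C(COc1ccc(C(=O)/C=C/c2ccccc2Br)cc1)N[C@H]1CCOC1=O`: 3540 nM
- compound 3 `CC(C)(C)c1ccc(/C=C/C(=O)c2ccc(OCC(=O)N[C@H]3CCOC3=O)cc2)cc1`: 6570 nM

Compound 1 has the lowest number of the three. Compound 2 sits within the scatter of it (a 1.1-fold higher number from compound 1 to compound 2 (0.04 log units; within the scatter)); compound 3 lies beyond it (a 2.0-fold higher number from compound 1 to compound 3 (0.31 log units; beyond the scatter)), and from compound 2 the same replacement reads a 1.9-fold higher number from compound 2 to compound 3 (0.27 log units; within the scatter).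

Compound 4 `O=C(COc1ccc(C(=O)/C=C/c2ccc(Br)cc2)cc1)N[C@H]1CCOC1=O` differs from compound 1 by 4-bromophenyl in place of 2-chlorophenyl on a double-bonded chain carbon bound to a double-bonded chain carbon. Among the measured compounds shown here, two steps bear on this. The halogen swap alone, a 1.1-fold higher number from compound 1 to compound 2 (0.04 log units; within the scatter), changed nothing. For the measured compounds named here, the only step that replaced the whole ring substituent, a 2.0-fold higher number from compound 1 to compound 3 (0.31 log units; beyond the scatter), weakened modestly. For compound 4 a step no larger than that is expected, a 1.4-fold higher number from compound 1 to compound 4 (0.14 log units; within the scatter), in the direction of a higher number. Compound 4 is therefore estimated at 4500 nM, within 2200 nM to 9500 nM.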

Compound 4, half-maximal inhibitory concentration: 51700 nM
Compound 4: the middle estimate sits 11-fold (1.06 log units) below what was measured, outside the stated range (above it).
By their numbers in this assay, from the lowest: compounds 1, 2 and 3 (each within the scatter of the next, the first and the last beyond it); then compound 4.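

Moving the same bromo from 2-bromophenyl to 4-bromophenyl, on a double-bonded chain carbon bound to a double-bonded chain carbon, is far from neutral (a 15-fold higher number from compound 2 to compound 4 (1.16 log units; beyond the scatter)), and the step from 2-chlorophenyl reads much the same (a 16-fold higher number from compound 1 to compound 4 (1.20 log units; beyond the scatter)). Having a group in the 4-position of this ring does not by itself set the loss, as bromo in place of tert-butyl also moves the number (a 7.9-fold higher number from compound 3 to compound 4 (0.90 log units; beyond the scatter)). Nothing available explains these steps.

Going by these compounds, it remains open whether 4-chlorophenyl, 4-aminophenyl or 4-carboxyphenyl would track compound 3 or compound 4.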